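The source may report more compounds than this note shows. Statements on the series, on what has been measured and on what is new or still open speak of the compounds shown alone.

Compound 1 `CC(CC(=O)O)CC(=O)c1c(CCCCCCc2ccccc2)n(C)c2ccc(Cl)cc12`: 568000 ng.h/mL
Compound 2 `CC(CC(=O)O)CC(=O)n1c(CCCCCc2ccccc2)cc2ccc(Cl)cc21`: 125000 ng.h/mL

Both numbers come from an ADME assay on the whole organism (plasma) for pharmacokinetics, with Cynomolgus monkey (Macaca fascicularis) as the target, read by HPLC, with a stated time of 24 h, at a dose of 30 mg/kg by the oral route; on this read-out lower numbers stand for lower exposure and higher numbers for higher exposure at the dose given. Compound 1, at 568000 ng.h/mL, stands highest of the two, and the gap down to compound 2, at 125000 ng.h/mL, lies beyond the usual scatter. The two differ in more than one place, so that gap says nothing about any single change.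

The next compound is compound 3 `C[C@H](CC(=O)O)CC(=O)c1c(CCCCCCc2ccccc2)n(C)c2ccc(Cl)cc12`, and its change from compound 1 is a subtle one: the two compounds have the same atoms and bonds; at least one stereo element is drawn with a configuration in one of them and without one in the other: 1 of 1 stereo elements differ; a stereocentre at a saturated chain carbon is drawn without a configuration in compound 1 and S in compound 3. The two compounds have the same atoms and bonds. A stereocentre at a saturated chain carbon is drawn without a configuration in compound 1 and S in compound 3. A stereocentre is a carbon whose groups can be arranged in two mirror-image ways.

Within the data shown here, no measured pair shows what such a change does in this assay, so compound 1 at 568000 ng.h/mL is the only sensible anchor. The expected size of the step is none beyond the scatter, and its direction is open: a 1.0-fold lower number from compound 1 to compound 3 (0.01 log units; within the scatter). Compound 3 is estimated at 550000 ng.h/mL, with an expected range from 270000 ng.h/mL to 1100000 ng.h/mL.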

Compound 3, area under the concentration-time curve: 311000 ng.h/mL
Compound 3: middle estimate off by 1.8-fold (0.25 log units), on the high side; low and high end bracket the measured number.
By their numbers in this assay, from the lowest: compound 2; then compounds 3 and 1 (each within the scatter of the next).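

Among these compounds, compound 3 gives the first reading of a single change in this assay: setting the stereocentre at a saturated chain carbon as S, where compound 1 has it drawn without a configuration, comes with a 1.8-fold lower number from compound 1 to compound 3 (0.26 log units; within the scatter). At this position, then, the defined S form and the undefined drawing cannot be told apart on exposure, something the gap between compound 1 and compound 2 could not show, since those two differ in more than one place. This pair shares all its atoms and bonds, so only one thing separates the two: the fact that one of compounds 1 and 3 is drawn with a defined configuration and the other without, at the place where they differ

How the R arrangement at this stereocentre would read in this assay remains an open question, and a single pair gives no sense of how much stereochemistry at this carbon can matter. Also open, from the compounds shown here alone, is how exposure would respond to a change of another kind at the same end of the molecule, such as a primary amide or a tetrazole in place of the carboxylic acid, or a second methyl group on the stereocentre carbon.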